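The source may report more compounds than this note shows. Statements on the series, on what has been measured and on what is new or still open speak of the compounds shown alone.

For the measured compounds named here, in a functional assay on the whole organism with Rattus norvegicus as the target, with a stated time of 4 h, at a dose of 40 mg/kg by the intraperitoneal route (on this read-out lower numbers stand for less inhibition and higher numbers for more inhibition at the one dose given (going by the name of the read-out)), compound 1 `Cc1nc2c(OCc3ccccc3)cccn2c1C(N)=O` gives 42%, while compound 2 `[C-]#[N+]Cc1c(C)nc2c(OCc3ccccc3)cccn12` gives 96%, the higher of the two numbers measured so far. Going by the values given here, the only measured step, a number 54 percentage points higher from compound 1 to compound 2 (beyond the scatter), altered a different group on the shared core than the one changed here, so it offers little direct guidance. Compound 3 `COCc1c(C)nc2c(OCc3ccccc3)cccn12` differs from compound 2 by a group of 2 heavy atoms (1 carbon, 1 oxygen; no ring) in place of a group of 2 heavy atoms (1 carbon, 1 nitrogen; no ring), on a saturated chain carbon bound to an aromatic carbon. Among the compounds with values here, with no closely related step to lean on, a moderate fall toward the middle of the two measured numbers is expected, giving a step of a number 31 percentage points lower from compound 2 to compound 3 (beyond the scatter). Compound 3 is therefore estimated at 65%, with a likely range from 30% to 95%.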

Compound 3, a percentage reported as inhibition, in the whole organism at one dose (the size of the read-out at that dose, not a potency): 99%
Estimate against measurement, compound 3: 34 percentage points below; measured number above the stated range.
By their numbers in this assay, from the lowest: compound 1; then compounds 2 and 3 (each within the scatter of the next).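

In this assay, methoxy in place of the group with the triple bond, on a saturated chain carbon bound to an aromatic carbon, gives a number 3 percentage points higher from compound 2 to compound 3 (within the scatter), so this read-out does not separate the two groups. Methoxymethyl in place of carbamoyl on an aromatic carbon gives a number 57 percentage points higher from compound 1 to compound 3 (beyond the scatter), which leaves the carbamoyl compound apart from the other two. Nothing measured here explains this result. From the compounds shown here alone, whether an amine, a carboxylic acid or a longer chain at this place would hold the number up remains open. The single dose also leaves any difference in potency between these compounds unknown.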